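One Methyl More: The Same Kind of Change, Twice

The source may hold more compounds than are shown below. What is called first, only, known or untested is meant among the compounds shown, and "the series" means these compounds.

Compound 1 `CCCc1ccc(-c2cc(Cl)cc(C(=O)Nc3nn[nH]n3)n2)cc1` gives 78% in a functional assay on the whole organism with Rattus norvegicus as the target, at a dose of 1 mg/kg by the oral route; a lower number here means a weaker effect, a higher number a stronger effect of the compound at the dose given. Compound 2 `CCCCc1ccc(-c2cc(Cl)cc(C(=O)Nc3nn[nH]n3)n2)cc1` gives 0% in this assay. The step between them is a number 78 percentage points lower from compound 1 to compound 2 (beyond the scatter), and the change behind it is methyl in place of hydrogen on a saturated chain carbon, three bonds along the chain from an aromatic carbon. Compound 3 `COc1cc(C(=O)Nc2nn[nH]n2)nc(-c2ccc(C)cc2)c1` gives 42% in this assay; how its core differs from that of compound 1 is not broken down here. Compound 4 `CCOc1cc(C(=O)Nc2nn[nH]n2)nc(-c2ccc(C)cc2)c1` is not yet measured and differs from compound 3 by methyl in place of hydrogen on a saturated chain carbon bound to an oxygen on an aromatic ring. This is the same kind of change as that between compound 1 and compound 2, but not the same one: there the methyl entered three bonds along the chain from an aromatic carbon, here it enters on a saturated chain carbon bound to an oxygen on an aromatic ring. Because a number 78 percentage points lower from compound 1 to compound 2 (beyond the scatter) was large and downward, a drop is expected here too, though the differing place leaves it uncertain. The expected step is a number 27 percentage points lower from compound 3 to compound 4 (beyond the scatter). Compound 4 is estimated to give 15% in this assay.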

Compound 4, a percentage reported as inhibition, in the whole organism at one dose (the size of the read-out at that dose, not a potency): 65%
For compound 4 the middle estimate is 50 percentage points below the measured one; measured number above the stated range.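

In this assay the added methyl gave a number 23 percentage points higher from compound 3 to compound 4 (beyond the scatter), whereas the earlier addition gave a number 78 percentage points lower from compound 1 to compound 2 (beyond the scatter). In this series, then, the same kind of change did not carry from one core to the other in either direction or size: the same change on two cores in this assay, a number 78 percentage points lower (beyond the scatter) from compound 1 to compound 2 and a number 23 percentage points higher (beyond the scatter) from compound 3 to compound 4, 101 percentage points apart, beyond the scatter of two such steps These two pairs do not show what separates the steps, as the cores differ and the methyl also enters at a different place in each pair, so neither can be singled out.

The compounds shown leave open whether a longer chain on the oxygen would raise or lower the read-out further. They also leave open how an amine in place of the ethoxy would compare.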